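A Cyclohexenyl Swap at a Low Level of Activity

The compounds below may be only part of what the source reports. "The series", "measured", "known", "first", "only" and "open" are said of these compounds alone.

Of the compounds shown here, three have been measured in a functional assay on MDA-MB-231 cells (Homo sapiens) for antiproliferative activity, read by MTT assay, with a stated time of 48 h; on this read-out lower numbers stand for stronger inhibition and higher numbers for weaker inhibition. Compound 1 (`C=CS(=O)(=O)N1CCN(c2ccn3ncc(-c4ccccc4)c3n2)CC1`) gives 38300 nM, compound 2 (`C=CS(=O)(=O)N1CCN(c2ncnc3sc(-c4ccnc(Cl)c4)cc23)CC1`) gives 27700 nM, and compound 3 (`C=CS(=O)(=O)N1CCN(c2ncnc3sc(-c4cnn(Cc5ccccc5)c4)cc23)CC1`) gives 19100 nM. Compound 2 stands among these three numbers, within the scatter of both compound 1 and compound 3.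

Compound 4 (`C=CS(=O)(=O)N1CCN(c2ncnc3sc(C4=CCCCC4)cc23)CC1`) has not yet been measured. It carries cyclohex-1-en-1-yl in place of the 2-chloropyridin-4-yl of compound 2, on an aromatic carbon of a five-membered aromatic ring with 1 sulfur, next to the ring sulfur: cyclohex-1-en-1-yl in place of 2-chloropyridin-4-yl on an aromatic carbon.

Among the measured compounds shown here, no measured pair of compounds offers a step for a change at one place, so the data give no direct precedent for this exchange in this assay. The expectation therefore rests on the narrow spread around compound 2, whose value of 27700 nM lies within the scatter of compound 3 at 19100 nM. The expected change is a 1.3-fold lower number from compound 2 to compound 4 (0.10 log units; within the scatter), which would be no step beyond the scatter. Compound 4 is estimated at 22000 nM, with an expected range from 9000 nM to 50000 nM.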

Compound 4, half-maximal inhibitory concentration: > 50000 nM
Compound 4 was reported as a limit; the forecaster's own chance of this, stated with the estimate: 10%; at least 2.2-fold (0.35 log units) between middle value and limit.
By their numbers in this assay, from the lowest: compounds 3, 2 and 1 (each within the scatter of the next). At a limit, above all of these: compound 4.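

Compound 4 provides the first comparison at a single place among these compounds, and in this assay compound 4 stands at > 50000 nM as a limit of the assay, not a number. Exchanging 2-chloropyridin-4-yl for cyclohex-1-en-1-yl on this aromatic carbon, next to the ring sulfur, gives an at least 1.8-fold higher number from compound 2 to compound 4 (0.25 log units; that floor lies within the scatter) and so shows no gain from the change, while a floor within the scatter does not by itself establish a loss. From the compounds shown here alone, the true size of the step stays unknown because the reading ends at the assay limit: the limit of > 50000 nM in this assay, at which 1 of the 4 values shown sits.

The compounds shown do not tell whether the aromatic character of the ring at this carbon matters, since the exchange also removes the ring nitrogen and the chlorine together, and a 4-aminophenyl or a 4-carboxyphenyl group here would each be a separate question. Nor do they tell how a saturated cyclohexyl ring or a short chain such as n-butyl would read on this carbon in this assay, or whether compound 4 would give a number under a wider concentration range.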